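A few compounds are considered here, and "the series" means these few. Any claim that something is new, unique, unknown or untested is made for them only; others in the source may bear on it.

Values in an ADME assay on BJ cells (Homo sapiens) for cytotoxicity, read by CellTiter-Glo and resazurin assay, with a stated time of 72 h (a higher number here means that more compound is needed for the effect, a lower number that less compound is needed), both of them limits:
- compound 1 `CC(C)N(Cc1cccc(OCCCCCC(=O)O)c1)C(=O)c1ccc(-c2cccc3ccccc23)cc1`: < 1.3 nM
- compound 2 `CC(=O)c1cccc(-c2ccc(C(=O)N(Cc3cccc(OCCCCCC(=O)O)c3)C(C)C)cc2)c1`: > 26000 nM

Not yet measured: compound 3 `CC(C)N(Cc1cccc(OCCCCCC(=O)O)c1)C(=O)c1ccc(-c2ccoc2)cc1`.

Compound 2 stands at > 26000 nM, which is a limit and not a number. Going to compound 3 replaces the group on the same aromatic carbon: furan-3-yl in place of 3-acetylphenyl (furan-3-yl in place of 3-acetylphenyl on an aromatic carbon). Among the compounds with values here, one measured step bears on this, a large one at that carbon with naphthalen-1-yl leaving: an at least 20000-fold higher number from compound 1 to compound 2 (4.30 log units; beyond the scatter). That single step shows how far an exchange here can move this assay, but furan-3-yl, like 3-acetylphenyl, is a single aromatic ring, so compound 3 is expected to stay close to compound 2. The expected change is an at least 1.3-fold lower number from compound 2 to compound 3 (0.11 log units; that floor lies within the scatter), which means no step beyond the scatter is expected, although a fall remains possible. The estimate for compound 3 is 20000 nM, with an expected range of 1500 nM to 60000 nM.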

Compound 3, half-maximal effective concentration: > 26000 nM
Compound 3: no number, only a limit; the forecaster's own chance of this, stated with the estimate: 60%; middle value at least 1.3-fold (0.11 log units) from the limit.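

In this assay, compound 3 gives > 26000 nM, a limit, so furan-3-yl with its five-membered aromatic ring ends at the same limit as 3-acetylphenyl with its six-membered one. The exchange of naphthalen-1-yl for furan-3-yl gives an at least 20000-fold higher number from compound 1 to compound 3 (4.30 log units; beyond the scatter), so the large step at this carbon now holds for two different single aromatic rings and no longer rests on 3-acetylphenyl alone. No order between furan-3-yl and 3-acetylphenyl can be read, as the two limits leave that step unreadable, and both compounds rest at one end of the read-out: the limit of > 26000 nM in this assay, at which 2 of the 3 values shown sit.

Still open, on these data alone, is whether naphthalen-2-yl or a quinolinyl group at this carbon would keep the effect of naphthalen-1-yl. Also open, as far as these compounds go, are the true values behind all three limits, which leaves the full size of these steps unknown.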